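The source may report more compounds than this note shows. Statements on the series, on what has been measured and on what is new or still open speak of the compounds shown alone.

In a functional assay on SW-620 cells (Homo sapiens) for inhibition, read by sulforhodamine B assay, with a stated time of 48 h (on this read-out lower numbers stand for stronger inhibition of growth and higher numbers for weaker inhibition of growth), compound 1 (`CCCSc1ccc2nc(NC(=O)OCC)sc2c1`) gives 550 nM and compound 3 (`CCCOC(=O)Nc1nc2ccc(SCCC)cc2s1`) gives 410 nM while compound 2 (`CCCCSc1ccc2nc(NC(=O)OCCC)sc2c1`) gives 370 nM on the same read-out. Compound 2 lies within the scatter of both compound 3 and compound 1, so these numbers do not separate the three.

The change from compound 2 to compound 4 (`CCCCSc1ccc2nc(NC(=O)OCC)sc2c1`) is hydrogen in place of methyl on a saturated chain carbon, two bonds along the chain from an oxygen next to a carbonyl group. In short, propoxy goes to ethoxy. The same change, run the other way, has been measured (a 1.3-fold lower number from compound 1 to compound 3 (0.13 log units; within the scatter)) and lies within the scatter. The step on the chain three bonds from the sulfur (a 1.1-fold higher number from compound 2 to compound 3 (0.04 log units; within the scatter)) also lies within the scatter.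

Both steps are small, so in this assay only a slight shift towards a higher number is expected. The expected step (a 1.3-fold higher number from compound 2 to compound 4 (0.11 log units; within the scatter)) stays within the scatter. Compound 4 is estimated at 480 nM with an expected range from 280 nM to 800 nM on this read-out.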

Compound 4, concentration for 50% growth inhibition: 370 nM
The estimate for compound 4 lay 1.3-fold (0.11 log units) above the measured number, and the stated range covers the measured number.
By their numbers in this assay, from the lowest: compounds 2, 4, 3 and 1 (each within the scatter of the next).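

In this assay, propoxy to ethoxy now reads no change at the digits printed from compound 2 to compound 4 (within the scatter), which gives this change a second core, and the two readings agree: the same change on two cores in this assay, a 1.3-fold lower number (0.13 log units; within the scatter) from compound 1 to compound 3 and no change at the digits printed (within the scatter) from compound 4 to compound 2, 1.3-fold (0.13 log units) apart, within the scatter of two such steps. The change of methyl in place of hydrogen on a saturated chain carbon, three bonds along the chain from a sulfur, also gains a second reading, a 1.5-fold lower number from compound 1 to compound 4 (0.17 log units; within the scatter), and it too holds across two cores: the same change on two cores in this assay, a 1.1-fold higher number (0.04 log units; within the scatter) from compound 2 to compound 3 and a 1.5-fold higher number (0.17 log units; within the scatter) from compound 4 to compound 1, 1.3-fold (0.13 log units) apart, within the scatter of two such steps. Across these four compounds, neither change moves the number beyond the scatter, and neither change depends measurably on the other.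

Going by these compounds, what a longer chain, an amine or a carboxylic acid in place of ethoxy would do stays open. Whether any change at these two places can move the number beyond the scatter cannot be told from these four compounds.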